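The source may hold more compounds than are shown below. What is called first, only, known or untested is meant among the compounds shown, and "the series" means these compounds.

Measured compounds:
Compound 1 `CC(Oc1cccnc1Nc1cnn(C)c1)c1cccc(C(=O)NCc2ccc(OC(F)(F)F)cc2)c1` gives 8300 nM in a functional assay on NCI-H3122 cells (Homo sapiens) for antiproliferative activity, read by MTT assay, with a stated time of 48 h; on this read-out lower numbers stand for stronger inhibition and higher numbers for weaker inhibition.
Compound 2 `Cc1ccc(CNC(=O)c2cccc(C(C)Oc3ccnc(Nc4cnn(C5CCN(C)CC5)c4)c3)c2)cc1` gives 8900 nM in this assay.
Compound 3 `CC(Oc1ccnc(Nc2cnn(C3CCN(C)CC3)c2)c1)c1cccc(C(=O)NCc2ccc(Cl)c(C(F)(F)F)c2)c1` gives 8000 nM in this assay.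

The three numbers lie close together. Compound 2 differs from compound 1 and from compound 3 only within the scatter, so none of the three can be called the more or less potent. Among the measured compounds shown here, the one directly comparable pair, compound 2 and compound 3, shows a 1.1-fold lower number from compound 2 to compound 3 (0.05 log units; within the scatter), which is a change at the amide end and not at the aromatic amine.

Compound 4 `Cc1ccc(CNC(=O)c2cccc(C(C)Oc3ccnc(Nc4nc5ccccc5[nH]4)c3)c2)cc1` carries 1H-benzimidazol-2-yl in place of 1-(1-methylpiperidin-4-yl)-1H-pyrazol-4-yl on a nitrogen on an aromatic ring. For the measured compounds named here, no measured pair among compounds 1, 2 and 3 varies this part of the molecule, so no step bears directly on the change; the only guide is that the three compounds, with different groups at both ends, all sit in the same narrow band of this assay. On that basis the estimate for compound 4 is a 1.1-fold higher number from compound 2 to compound 4 (0.05 log units; within the scatter), a step not expected to exceed the scatter. Compound 4 is therefore expected to give about 10000 nM, with a range of 3000 nM to 30000 nM.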

Compound 4, half-maximal inhibitory concentration: 9400 nM
Compound 4: the middle estimate sits 1.1-fold (0.03 log units) above what was measured; low and high end bracket the measured number.
By their numbers in this assay, from the lowest: compounds 3, 1, 2 and 4 (each within the scatter of the next).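

In this assay, among the compounds shown here, the step of a 1.1-fold higher number from compound 2 to compound 4 (0.02 log units; within the scatter) gives the first reading at this position, where 1H-benzimidazol-2-yl replaces 1-(1-methylpiperidin-4-yl)-1H-pyrazol-4-yl on a nitrogen on an aromatic ring. With the 4-methylphenyl group held constant at the amide end, this exchange removes the six-membered non-aromatic ring and brings in a hydrogen-bond donor, yet the change in the number stays within the scatter. No measurement shown here accounts for this result.

The compounds shown leave open whether the 1H-benzimidazol-2-yl group would give the same result alongside 4-chloro-3-(trifluoromethyl)phenyl at the amide end. They also leave open whether a different group on this nitrogen, such as a carboxylic acid or a morpholine-bearing phenyl, would move the number beyond the scatter.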